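Phenoxy for acetamido on the biaryl tail of compound 3

The compounds below may be only part of what the source reports. "The series", "measured", "known", "first", "only" and "open" are said of these compounds alone.

Compound 1 `CC(C)N(Cc1cccc(OCCCCCC(=O)O)c1)C(=O)c1ccccc1`: in an ADME assay on BJ cells (Homo sapiens) for cytotoxicity, read by CellTiter-Glo and resazurin assay, with a stated time of 72 h (a lower number here means that less compound is needed, a higher number that more compound is needed for the effect), compound 1 reached only the limit > 26000 nM.
Compound 2 `CC(C)N(Cc1cccc(OCCCCCC(=O)O)c1)C(=O)c1ccc(-c2cccc3ccccc23)cc1`: in this assay compound 2 reached only the limit < 1.3 nM.
Compound 3 `CC(=O)Nc1cccc(-c2ccc(C(=O)N(Cc3cccc(OCCCCCC(=O)O)c3)C(C)C)cc2)c1`: in this assay compound 3 reached only the limit > 26000 nM.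

Compound 3 therefore stands at the limit of > 26000 nM in this assay, at which 2 of the 3 values shown sit, while compound 2 sits at the limit of < 1.3 nM in this assay, at which 1 of the 3 values shown sits. The steps show how wide this series spreads: an at least 20000-fold lower number from compound 1 to compound 2 (4.30 log units; beyond the scatter) and an at least 20000-fold higher number from compound 2 to compound 3 (4.30 log units; beyond the scatter), whereas a step that the two limits leave unreadable from compound 1 to compound 3. Compound 4 `CC(C)N(Cc1cccc(OCCCCCC(=O)O)c1)C(=O)c1ccc(-c2cccc(Oc3ccccc3)c2)cc1` has not been tested in this assay; it differs from compound 3 in one place: phenoxy in place of acetamido on an aromatic carbon. The only step that bears on it is the one from compound 2 to compound 3, in which the aryl group on the same aromatic carbon was swapped and the number moved by a large amount; the step to compound 4 swaps only a group on that aryl ring, so its size cannot be read from the steps shown. Compound 4 is expected to fall between the two limits, an estimate of 500 nM with a range from 10 nM to 26000 nM, which is meant as an at least 52-fold lower number from compound 3 to compound 4 (1.71 log units; beyond the scatter).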

Compound 4, half-maximal effective concentration: > 18700 nM
Compound 4 ended at the assay's limit; the forecaster's own chance of this, stated with the estimate: 30%; middle value at least 37-fold (1.57 log units) from the limit.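

For the compounds shown here, compound 3 and compound 4 both carry limits rather than numbers, and no step between them can be read. The compounds shown leave open how far each lies beyond its limit, and whether phenoxy in place of acetamido shifts the number at all.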